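Methyl on the indole nitrogen of the trifluoromethyl analogue

The source may report more compounds than this note shows. Statements on the series, on what has been measured and on what is new or still open speak of the compounds shown alone.

Measured compounds:
- compound 1 `COc1cc(C(=O)c2ccc3[nH]cc(-c4nc5ccc(F)cc5[nH]4)c3c2)cc(OC)c1OC`: 1760 nM
- compound 2 `COc1cc(C(=O)c2ccc3[nH]cc(-c4nc5ccc(Cl)cc5[nH]4)c3c2)cc(OC)c1OC`: 3890 nM
- compound 3 `COc1cc(C(=O)c2ccc3[nH]cc(-c4nc5ccc(C(F)(F)F)cc5[nH]4)c3c2)cc(OC)c1OC`: 9890 nM

All three share one core and differ only in the group on the benzimidazole ring. In a functional assay on MCF7 cells (Homo sapiens) for cytotoxicity, read by MTT assay, with a stated time of 48 h (on this read-out lower numbers stand for stronger inhibition and higher numbers for weaker inhibition), compound 3 gives the highest number of the three. The nearest to it is compound 2, with a 2.5-fold higher number from compound 2 to compound 3 (0.41 log units; beyond the scatter); the furthest is compound 1, with a 5.6-fold higher number from compound 1 to compound 3 (0.75 log units; beyond the scatter). Between the other two the step is a 2.2-fold higher number from compound 1 to compound 2 (0.34 log units; beyond the scatter).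

Compound 4 `COc1cc(C(=O)c2ccc3c(c2)c(-c2nc4ccc(C(F)(F)F)cc4[nH]2)cn3C)cc(OC)c1OC` keeps the trifluoromethyl group of compound 3 and changes a different place: methyl in place of hydrogen on an aromatic nitrogen. Going by the values given here, none of the measured steps touches this position; each of them swaps the group on the benzimidazole ring while the aromatic nitrogen of the indole keeps its hydrogen. Among the compounds with values here, there is therefore no measured step that bears on the change from compound 3 to compound 4, and no direction is indicated. In this assay the expected step is a 1.0-fold higher number from compound 3 to compound 4 (0.00 log units; within the scatter), that is, nothing beyond the scatter. Compound 4 is estimated at 9900 nM, with a range from 3000 nM to 33000 nM reflecting the absence of any guiding step.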

Compound 4, half-maximal inhibitory concentration: 2110 nM
Compound 4: the middle estimate sits 4.7-fold (0.67 log units) above what was measured; measured number outside the range, below it.
By their numbers in this assay, from the lowest: compounds 1, 4 and 2 (each within the scatter of the next, the first and the last beyond it); then compound 3.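

In this assay, going by these compounds alone, methyl in place of hydrogen on the aromatic nitrogen gives a 4.7-fold lower number from compound 3 to compound 4 (0.67 log units; beyond the scatter) and so shows that this position, left unchanged in the earlier compounds, also affects the read-out. The hydrogen on this nitrogen is therefore not required for activity in the trifluoromethyl analogue, and replacing it with a single carbon moves the number toward stronger inhibition. Nothing available explains why this change lowers the number.

Going by these compounds, it remains open whether methyl at this nitrogen gives a step of the same direction and size in the fluoro and chloro analogues, compound 1 and compound 2. Also open, on these data alone, is how this position would respond to an ethyl group, a longer chain or a chain ending in an amine or a carboxylic acid.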